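Changing the Sulfur Chain of Compound 2

The source may report more compounds than this note shows. Statements on the series, on what has been measured and on what is new or still open speak of the compounds shown alone.

Among the compounds with values here, in a functional assay on HT cells (Homo sapiens) for antiproliferative activity, read by fluorescence, with a stated time of 72 h (on this read-out lower numbers stand for stronger inhibition of growth and higher numbers for weaker inhibition of growth), compound 2 `CC(=O)NCCSc1nc(NCc2ccc(-c3ccccn3)cc2)c2[nH]nc(C(C)C)c2n1` gives 71 nM and holds the lower of the two numbers so far, while compound 1 `CC(C)c1n[nH]c2c(NCc3ccc(-c4ccccn4)cc3)nc(SCC(O)C(F)(F)F)nc12` gives 690 nM as its only neighbour. Compound 3 `CCC(CO)Sc1nc(NCc2ccc(-c3ccccn3)cc2)c2[nH]nc(C(C)C)c2n1` differs from compound 2 on the sulfur, and 1-(hydroxymethyl)propyl in place of 2-acetamidoethyl on a sulfur is the change. Within the data shown here, the one measured step bearing on it is a 9.7-fold lower number from compound 1 to compound 2 (0.99 log units; beyond the scatter) and it also lies in that chain. One step fixes no direction for a new chain, so only a small rise is expected, and the estimated step is a 1.7-fold higher number from compound 2 to compound 3 (0.23 log units; within the scatter) in size. In this assay compound 3 is expected at 120 nM with an estimated range from 35 nM to 450 nM for the coming measurement.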

Compound 3, concentration for 50% growth inhibition: 255 nM
Compound 3: the middle estimate sits 2.1-fold (0.33 log units) below what was measured, within the range that was stated.
By their numbers in this assay, from the lowest: compound 2; then compound 3; then compound 1.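

Within this assay, the sulfur chain now separates three compounds: replacing 2-acetamidoethyl with 1-(hydroxymethyl)propyl gives a 3.6-fold higher number from compound 2 to compound 3 (0.56 log units; beyond the scatter), so a second hydroxyl-bearing chain also stands above compound 2. Yet the two hydroxyl-bearing chains are not equivalent, as the change shows a 2.7-fold lower number from compound 1 to compound 3 (0.43 log units; beyond the scatter). No available evidence explains these differences. It remains open whether a longer chain ending in the acetamide would lie below compound 2, and how a chain ending in an amine or a carboxylic acid would rank among these three.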